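A third group on the sulfonamide nitrogen

A few compounds are considered here, and "the series" means these few. Any claim that something is new, unique, unknown or untested is made for them only; others in the source may bear on it.

- Compound 1 `Cc1cc(C)nc(NS(=O)(=O)c2ccc(Nc3nncc4ccccc34)cc2)n1`: 0.56 nM
- Compound 2 `O=S(=O)(Nc1ccccn1)c1ccc(Nc2nncc3ccccc23)cc1`: 8.4 nM

For the measured compounds named here, in a functional assay on SF-295 cells (Homo sapiens) for antiproliferative activity, read by sulforhodamine B assay, with a stated time of 72 h (a lower number here means a stronger inhibitor, a higher number a weaker inhibitor), compound 2 gives 8.4 nM, the higher of the two numbers known so far. Compound 3 `Cc1cc(NS(=O)(=O)c2ccc(Nc3nncc4ccccc34)cc2)no1` keeps the shared core but carries 5-methyl-1,2-oxazol-3-yl in place of pyridin-2-yl on a sulfonamide nitrogen. Going by the values given here, one measured step bears on this change. It is a 15-fold higher number from compound 1 to compound 2 (1.18 log units; beyond the scatter), a large step beyond the scatter, with pyridin-2-yl in place of 4,6-dimethylpyrimidin-2-yl on the same nitrogen. That step shows that the number in this assay can shift strongly with the group at this place, but it does not show which way the new group will move it. Among the compounds with values here, no measured compound carries a five-membered ring here. With compound 2 at the upper end of the pair and compound 1 at 0.56 nM, a moderate move toward a lower number is expected, though the evidence is thin. The estimated change is a 2.4-fold lower number from compound 2 to compound 3 (0.38 log units; beyond the scatter). The expected value for compound 3 is 3.5 nM, with an estimated range from 0.6 nM to 15 nM.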

Compound 3, half-maximal inhibitory concentration: 4.4 nM
The estimate for compound 3 lay 1.3-fold (0.10 log units) below the measured number; the measured number falls inside the stated range.
By their numbers in this assay, from the lowest: compound 1; then compounds 3 and 2 (each within the scatter of the next).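

In this assay the step is a 1.9-fold lower number from compound 2 to compound 3 (0.28 log units; within the scatter) and so stays within the scatter, which shows that at this place on a sulfonamide nitrogen, a five-membered aromatic ring with 2 hetero atoms can take the place of a six-membered aromatic ring with 1 hetero atom without a change that can be told from the scatter. The comparison with the third group gives a 7.9-fold higher number from compound 1 to compound 3 (0.90 log units; beyond the scatter) and, unlike the earlier pair, shows that compound 1 stands apart from two different rings, so that its 4,6-dimethylpyrimidin-2-yl group alone among the three gives a number beyond the scatter of the others. Nothing measured here accounts for what sets compound 1 apart.

The compounds shown do not separate the two methyl groups of 4,6-dimethylpyrimidin-2-yl from its ring, nor the methyl group of 5-methyl-1,2-oxazol-3-yl from its ring. As far as these compounds go, how the number responds to a group without a ring on this nitrogen, such as a plain methyl or a longer chain, or to a carboxylic acid on one of these rings, also stays open.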